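Pyrimidinyl for methyl on a ring nitrogen of a dithiocarbamate

This account rests on a few compounds, and the source may have more. Where it says the series, first, only, none or still open, it means among the compounds named here.

Three compounds sharing one core were tested in an ADME assay on HeLa cells (Homo sapiens) for cytotoxicity, read by MTT assay, with a stated time of 24 h; on this read-out lower numbers stand for stronger inhibition and higher numbers for weaker inhibition. Compound 1 `CC1CCCN(C(=S)SC(=S)N(C)C)C1` gives 2900000 nM, compound 2 `CN1CCN(C(=S)SC(=S)N(C)C)CC1` gives 1220000 nM, and compound 3 `COc1ccccc1N1CCN(C(=S)SC(=S)N(C)C)CC1` gives 4330000 nM. Compound 2 stands at the lowest number of the three; compound 1 sits beyond the scatter above it, and compound 3 sits further above, also beyond the scatter.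

Compound 4 `CN(C)C(=S)SC(=S)N1CCN(c2ncccn2)CC1` has not been measured. Compared with compound 2, the change is pyrimidin-2-yl in place of methyl on an amine nitrogen in a ring. Of the measured compounds, compound 3, which carries an aromatic ring on the same ring nitrogen, gives a higher number than compound 2, whereas compound 2 with methyl in that position gives the lowest value; both pairs lie beyond the scatter. On that basis a step toward weaker inhibition in this assay is expected, of moderate size rather than none.

Compound 4 is estimated at 3000000 nM, within a range from 1200000 nM to 8000000 nM, which implies an expected step of a 2.5-fold higher number from compound 2 to compound 4 (0.39 log units; beyond the scatter).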

Compound 4, half-maximal inhibitory concentration: > 5000000 nM
Compound 4: only a limit was reported; the forecaster's own chance of this, stated with the estimate: 15%; at least 1.6-fold (0.22 log units) between middle value and limit.
By their numbers in this assay, from the lowest: compound 2; then compounds 1 and 3 (each within the scatter of the next). At a limit, above all of these: compound 4.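

In this assay compound 4 is reported only as a limit, > 5000000 nM. Pyrimidin-2-yl in place of methyl on this amine nitrogen in the ring gives an at least 4.0-fold higher number from compound 2 to compound 4 (0.61 log units; beyond the scatter), which shows that this position also responds to an aromatic ring with two hetero atoms, a kind of group that none of the earlier compounds carries there. The full size of the step cannot be read, and the figure is only its lower bound: the limit of > 5000000 nM in this assay, at which 1 of the 4 values shown sits.

On these data alone, what a plain phenyl, a longer alkyl chain or a hydroxyethyl group on this nitrogen would give remains open. As far as these compounds go, it is also open whether the step comes from the aromatic ring as such or from its ring nitrogens.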